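This account rests on a few compounds, and the source may have more. Where it says the series, first, only, none or still open, it means among the compounds named here.

Compound 1, `Cn1cncc1C(OCc1ccc(C#N)cc1-c1ccccc1)c1ccc(C#N)cc1`, in a functional assay on NIH3T3 cells (Mus musculus); on this read-out higher numbers stand for an effect only at larger amounts of compound and lower numbers for an effect already at smaller amounts: 140 nM
Compound 2, `Cn1cncc1C(OCc1ccc(C#N)cc1C#Cc1ccccn1)c1ccc(C#N)cc1`, in this assay: only a limit, > 0.1 nM
Compound 3, `Cn1cncc1C(OCc1ccc(C#N)cc1C#Cc1ccc(C#N)cc1)c1ccc(C#N)cc1`, in this assay: 11.6 nM

Compound 2 stands on no number at all: what it gives in this assay is a limit of the assay, (the limit of > 0.1 nM in this assay, at which 1 of the 3 values shown sits), so the steps a step that the limit leaves unreadable from compound 1 to compound 2 and a step that the limit leaves unreadable from compound 2 to compound 3 cannot be read. Within the data shown here, the one readable step is a 12-fold lower number from compound 1 to compound 3 (1.08 log units; beyond the scatter).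

Compound 4 is `Cn1cncc1C(OCc1ccc(C#N)cc1-c1ccc(-c2ccccc2)cc1)c1ccc(C#N)cc1`. It differs from compound 2 in this way: 4-phenylphenyl in place of 2-(pyridin-2-yl)ethynyl on an aromatic carbon. Among the measured compounds shown here, no measured step shows this change on its own. Compound 4 shares its phenyl attachment with compound 1, which gives 140 nM, but carries a second phenyl ring at the far end; compound 3 shows that a larger group at this position can go with a lower number, as the step of a 12-fold lower number from compound 1 to compound 3 (1.08 log units; beyond the scatter) shows, while compound 2 leaves its own side unreadable. Starting from the limit of compound 2, no step size can be named, so the expectation is an absolute one: compound 4 is estimated at 100 nM, within 15 nM to 700 nM.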

Compound 4, half-maximal effective concentration: < 0.1 nM
Compound 4 was reported as a limit (the forecaster's own chance of this, stated with the estimate: 10%); middle value at least 1000-fold (3.00 log units) away from the limit.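

The value of compound 4 in this assay is a limit of the assay, not a number. Putting the 4-phenylphenyl group in place of the 2-(pyridin-2-yl)ethynyl group gives a number no higher from compound 2 to compound 4 (the limit leaves the size open). Even so, it shows that this position tolerates much more than compound 1 suggested: adding a phenyl ring to the existing one gives an at least 1400-fold lower number from compound 1 to compound 4 (3.14 log units; beyond the scatter), and swapping the triple-bonded arm for the directly joined ring gives an at least 110-fold lower number from compound 3 to compound 4 (2.06 log units; beyond the scatter). Both steps lie beyond the scatter, so among the readable compounds, a 4-phenylphenyl group on this aromatic carbon goes with a far lower number than either the single phenyl or the 2-(4-cyanophenyl)ethynyl group.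

The steps that touch compound 2 cannot be read, which leaves the 2-(pyridin-2-yl)ethynyl group unplaced against the others. Going by these compounds, it also stays open whether an amine or a carboxylic acid on the far ring of the 4-phenylphenyl group would keep so low a number.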